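The compounds below may be only part of what the source reports. "The series", "measured", "known", "first", "only" and "open" are said of these compounds alone.

Of the compounds shown here, two have been measured in an ADME assay on MT4 cells (Homo sapiens) for cytotoxicity, read by MTT assay, with a stated time of 5 days (on this read-out higher numbers stand for lower toxicity in this test and lower numbers for higher toxicity in this test), so far. Compound 1 `N#Cc1ccc(Nc2nccc(OCc3ccccc3Cl)n2)cc1` gives 146000 nM, and compound 2 `N#Cc1ccc(Nc2nccc(OCc3cccc(F)c3)n2)cc1` gives 105000 nM. Among the measured compounds shown here, on these two numbers compound 2 sits alongside its only neighbour, since the sole measured step, a 1.4-fold lower number from compound 1 to compound 2 (0.14 log units; within the scatter), does not exceed the scatter of the test. The next compound, compound 3 `N#Cc1ccc(Nc2nccc(OCc3ccccc3)n2)cc1`, differs from compound 2 by hydrogen in place of fluoro on an aromatic carbon. For the measured compounds named here, the one measured step concerns a different part of the same benzyl group, an exchange of one halogen-bearing ring for another, and it stayed within the scatter, so it gives no sign that small changes on this ring move the read-out. Compound 3 is therefore expected to show a step of a 1.0-fold higher number from compound 2 to compound 3 (0.02 log units; within the scatter), that is, none beyond the scatter. The estimated value for compound 3 in this assay is 110000 nM, with a likely range from 55000 nM to 220000 nM.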

Compound 3, half-maximal cytotoxic concentration: 13000 nM
Compound 3: middle estimate off by 8.5-fold (0.93 log units), on the high side; the measured number lies below the stated range.
By their numbers in this assay, from the lowest: compound 3; then compounds 2 and 1 (each within the scatter of the next).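

Taking the halogen off the benzyl ring gives an 8.1-fold lower number from compound 2 to compound 3 (0.91 log units; beyond the scatter) in this assay and also an 11-fold lower number from compound 1 to compound 3 (1.05 log units; beyond the scatter) on the same read-out. The earlier step showed only that 3-fluorophenyl and 2-chlorophenyl could not be told apart; these new steps show that the plain phenyl ring stands apart from both, with higher toxicity in this test, so a single ring substituent can matter here even though swapping one halogen-bearing ring for the other did not. No measurement at hand explains why hydrogen differs so much from either halogen.

On these data alone, whether a halogen is needed at all remains open, since a methyl or methoxy group on this ring might behave like the halogens or like hydrogen. Because the chloro and fluoro groups also sit at different ring positions, the separate roles of the group and its position remain unresolved too.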